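A dimethoxyphenyl swap on compound 3

The compounds below may be only part of what the source reports. "The series", "measured", "known", "first", "only" and "open" are said of these compounds alone.

In a physicochemical assay for solubility, in phosphate buffer, measured as kinetic solubility, at pH 7.4 (a lower number here means a less soluble compound, a higher number a more soluble compound), compound 3 `CCc1ccccc1-c1nc(CN2CCC(C(=O)NCCCN3C[C@H](C)C[C@H](C)C3)CC2)c(C)o1` gives 55.9 ug/mL. Compound 1 `Cc1ccc(C)c(-c2nc(CN3CCC(C(=O)NCCCN4C[C@H](C)C[C@H](C)C4)CC3)c(C)o2)c1` gives 56.1 ug/mL. That puts the pair level, with a step of a 1.0-fold lower number from compound 1 to compound 3 (0.00 log units; within the scatter). Compound 2 `Cc1oc(-c2c(F)cccc2F)nc1CN1CCC(C(=O)NCCCN2C[C@H](C)C[C@H](C)C2)CC1` shows > 72 ug/mL, which is a limit of this assay and not a number.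

The next compound, compound 4 `COc1cccc(OC)c1-c1nc(CN2CCC(C(=O)NCCCN3C[C@H](C)C[C@H](C)C3)CC2)c(C)o1`, carries 2,6-dimethoxyphenyl in place of 2-ethylphenyl on an aromatic carbon. Two further measured swaps at this same place bear on it: an at least 1.2-fold higher number from compound 1 to compound 2 (0.10 log units; that floor lies within the scatter), and an at least 1.2-fold lower number from compound 2 to compound 3 (0.10 log units; that floor lies within the scatter). Both are floors that lie within the scatter, and the step between the level pair is within it too. No step beyond the scatter is therefore expected in this assay. The estimated change is a 1.1-fold higher number from compound 3 to compound 4 (0.04 log units; within the scatter). A reading at the limit of > 72 ug/mL in this assay, at which 1 of the 3 values shown sits, would be no surprise for the new compound. Compound 4 is expected at 62 ug/mL, with an estimated range from 38 ug/mL to 100 ug/mL.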

Compound 4, solubility: > 76 ug/mL
Compound 4: a limit, no number; the forecaster's own chance of this, stated with the estimate: 35%; middle value at least 1.2-fold (0.08 log units) from the limit.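

In this assay, the 2,6-dimethoxyphenyl group of compound 4 gives a limit, not a number, so only a floor can be read: the limit of > 76 ug/mL in this assay, at which 1 of the 4 values shown sits.

Against 2-ethylphenyl the reading is an at least 1.3-fold higher number from compound 3 to compound 4 (0.13 log units; that floor lies within the scatter), and against 2,5-dimethylphenyl it is an at least 1.3-fold higher number from compound 1 to compound 4 (0.13 log units; that floor lies within the scatter); neither floor on its own shows a real rise. What is new is that 2,6-difluorophenyl in compound 2 and 2,6-dimethoxyphenyl in compound 4 both end at a limit, while 2,5-dimethylphenyl in compound 1 and 2-ethylphenyl in compound 3 give numbers, a pattern that rests on these four compounds alone.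

The step from compound 2 to compound 4 cannot be read, with a limit on each side. As far as these compounds go, it also remains open whether a phenyl ring carrying an amine or a carboxylic acid at this position would reach the limit too.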